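The source may report more compounds than this note shows. Statements on the series, on what has been measured and on what is new or still open speak of the compounds shown alone.

Measured in a functional assay on HL-60 cells (Homo sapiens), read by calcium flux; on this read-out higher numbers stand for an effect only at larger amounts of compound and lower numbers for an effect already at smaller amounts:
Compound 1 `Cc1cc(Cc2ccc(C(F)(F)F)cc2)c(=O)n(CC(=O)Nc2ccc(Br)cc2)n1`: > 50000 nM
Compound 2 `Cc1cc(Cc2ccsc2)c(=O)n(CC(=O)Nc2ccc(Br)cc2)n1`: > 50000 nM

Both entries are limits of the assay, not numbers. Compound 2 therefore has no exact position, and the only thing known about it is its limit of > 50000 nM. Compound 1 offers no better anchor, and the picture so far is the limit of > 50000 nM in this assay, at which 2 of the 2 values shown sit.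

The next compound is compound 3 `COc1ccc(-c2cc(C)nn(CC(=O)Nc3ccc(Br)cc3)c2=O)cc1`. It carries 4-methoxyphenyl in place of the (thiophen-3-yl)methyl of compound 2, on an aromatic carbon of a six-membered aromatic ring with 2 nitrogen. The counted difference is 4-methoxyphenyl in place of (thiophen-3-yl)methyl on an aromatic carbon.

For the measured compounds named here, only one measured step bears on this change, and it is a step that the two limits leave unreadable from compound 1 to compound 2. That step has no size to carry forward, so no shift beyond the usual scatter is expected in this assay, and neither direction is favoured. The expected change is an at least 1.2-fold lower number from compound 2 to compound 3 (0.09 log units; that floor lies within the scatter). The most likely result is another limit rather than a readable number. For compound 3 the estimated value is 40000 nM, within an expected range of 10000 nM to 50000 nM.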

Compound 3, half-maximal effective concentration: > 50000 nM
Compound 3: only a limit was reported; the forecaster's own chance of this, stated with the estimate: 70%; middle value at least 1.2-fold (0.09 log units) away from the limit.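

Compound 3 gives only a limit of the assay, as compound 2 does, so the step between compound 2 and compound 3 cannot be read and no size can be given for it. The compounds shown leave open which change to the shared core, if any, would give a readable number in this assay: the limit of > 50000 nM in this assay, at which 3 of the 3 values shown sit.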